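A few compounds are considered here, and "the series" means these few. Any claim that something is new, unique, unknown or untested is made for them only; others in the source may bear on it.

Of the compounds shown here, three have so far been measured in an assay on isolated protein for displacement of a labelled ligand from metabotropic glutamate receptor 5 (Homo sapiens), with a stated time of 60 min, tested at 1 uM; on this read-out higher numbers stand for more inhibition at the one concentration tested (going by the name of the read-out) and lower numbers for less inhibition. Compound 1 `Cc1ccc(S(=O)(=O)c2cnc3cc(Cl)ccc3c2N2CCC(C)CC2)cc1F` gives 85%, and compound 2 `CC1CCN(c2c(S(=O)(=O)c3ccc(F)c(F)c3)cnc3cc(Cl)ccc23)CC1` gives 90%. These two differ in one place, (methyl in place of fluoro on an aromatic carbon), and the step of a number 5 percentage points lower from compound 2 to compound 1 (within the scatter). Compound 3 `CC1CCN(c2c(S(=O)(=O)c3ccccc3)cnc3ccc(F)cc23)CC1` stands apart from both: in this assay compound 3 gives 40%, the lowest of the three numbers, and its gap to each of the other two lies beyond the scatter. How the core of compound 3 differs from the core of compound 2 is not broken down here.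

Compound 4 `Cc1ccc2ncc(S(=O)(=O)c3ccccc3)c(N3CCC(C)CC3)c2c1` remains to be measured. It differs from compound 3 by methyl in place of fluoro on an aromatic carbon. Within the data shown here, this is the same kind of change as the one from compound 2 to compound 1, but not the same: in compound 1 the methyl sits on a six-membered aromatic ring of carbon only, ortho to a fluoro group and para to a large group, whereas in compound 4 it sits on a six-membered aromatic ring of carbon only that is part of a fused or bridged system of two rings, meta to a fused ring and para to a fused ring.

Because a number 5 percentage points lower from compound 2 to compound 1 (within the scatter), the same kind of change is expected to move compound 4 by a step of roughly a number 5 percentage points higher from compound 3 to compound 4 (within the scatter) from compound 3. For compound 4 the estimate is therefore 45%, expected to fall between 25% and 65%.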

Compound 4, a percentage reported as inhibition, at one concentration (the size of the read-out at that concentration, not a potency): 67%
Compound 4: the middle estimate sits 22 percentage points below what was measured; the measured number lies above the stated range.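

In this assay, methyl in place of fluoro on an aromatic carbon gives a number 27 percentage points higher from compound 3 to compound 4 (beyond the scatter), a change made on a six-membered aromatic ring of carbon only that is part of a fused or bridged system of two rings. The same kind of change therefore does not carry a single step size from one core to the other in this series: the same change on two cores in this assay, a number 5 percentage points lower (within the scatter) from compound 2 to compound 1 and a number 27 percentage points higher (beyond the scatter) from compound 3 to compound 4, 32 percentage points apart, beyond the scatter of two such steps This does not show why the two steps differ, since the pairs differ both in their cores and in the ring that carries the change, and two pairs cannot separate these factors or predict the step on a third core; the numbers are also inhibition at one concentration and not potencies.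

The compounds shown leave open how a methoxy group, a nitrile or an amine would fare in this assay at the place where compound 3 carries fluoro and compound 4 carries methyl. They also leave open whether methyl in place of fluoro would give a step of similar size at other places on the core of compound 3.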